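The source may report more compounds than this note shows. Statements on the series, on what has been measured and on what is new or still open speak of the compounds shown alone.

Compound 1 `O=C(Nc1cccc(-n2cc(-c3ccncc3)c(-c3cc(O)cc(Cl)c3)n2)c1)Nc1ccc(Cl)c(C(F)(F)F)c1` gives in a functional assay on OVCAR-5 cells (Homo sapiens) for inhibition, read by sulforhodamine B assay, with a stated time of 48 h, tested at 10 uM (a higher number here means a weaker effect of the compound at the concentration tested, a lower number a stronger effect), 59.3%. Compound 2 `COc1cc(Cl)cc(-c2nn(-c3cccc(NC(=O)Nc4ccc(Cl)c(C(F)(F)F)c4)c3)cc2-c2ccncc2)c1` carries methyl in place of hydrogen on an oxygen on an aromatic ring and in this assay compound 2 gives 19.2%, so the change gave a number 40.1 percentage points lower from compound 1 to compound 2 (beyond the scatter). Compound 3 `O=C(Nc1cccc(-n2cc(-c3ccncc3)c(-c3cc(O)cc(Cl)c3)n2)c1)c1cc(C(F)(F)F)cc(C(F)(F)F)c1` shares the urea-free core with neither; how its core differs from that of compound 1 is not broken down here. In this assay compound 3 gives 70.7%, the highest number among the three measured compounds. Compound 4 `COc1cc(Cl)cc(-c2nn(-c3cccc(NC(=O)c4cc(C(F)(F)F)cc(C(F)(F)F)c4)c3)cc2-c2ccncc2)c1` carries the same change relative to compound 3, (methyl in place of hydrogen on an oxygen on an aromatic ring), with the place described in the same words as for compound 2; the change occurs twice among the compounds shown. Among the compounds with values here, a step of the same kind is expected, a number 35.7 percentage points lower from compound 3 to compound 4 (beyond the scatter), resting on the single earlier step of a number 40.1 percentage points lower from compound 1 to compound 2 (beyond the scatter). Compound 4 is thus expected near 35%, between 15% and 60%.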

Compound 4, a percentage reported as activity, at one concentration (the size of the read-out at that concentration, not a potency): 83%
Estimate against measurement, compound 4: 48 percentage points below; measured number outside the range, above it.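

In this assay the change from hydroxy to methoxy gave a number 12.3 percentage points higher from compound 3 to compound 4 (beyond the scatter), so the step seen on the core of compound 1 did not carry over to the core of compound 3 in either direction or size: the same change on two cores in this assay, a number 40.1 percentage points lower (beyond the scatter) from compound 1 to compound 2 and a number 12.3 percentage points higher (beyond the scatter) from compound 3 to compound 4, 52.4 percentage points apart, beyond the scatter of two such steps

For these two pairs, the effect of this methyl cannot be transferred as a fixed increment from one core to the other. Two pairs do not show which feature of the cores sets the difference, nor how the change would behave on any third core.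

Still open, as far as these compounds go, is how a longer chain on that oxygen, such as ethyl, would behave on each core. Also open, from the compounds shown here alone, is whether an amine in place of the hydroxy would follow either step.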